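The source may hold more compounds than are shown below. What is called first, only, known or untested is meant among the compounds shown, and "the series" means these compounds.

Measured compounds: compound 1 `CCc1nc2ccccc2n1CCCCOc1ccccc1` with 21 uM; compound 2 `CCc1nc2ccccc2n1CCCCOc1ccc(C)c(Cl)c1` with 14 uM; compound 3 `Cc1ccc2nc(C(C)O)n(CCCCOc3ccccc3)c2c1` with "not determined" (no result reported).

In an ADME assay on Vero cells (Chlorocebus sabaeus) for cytotoxicity, read by luminescence, with a stated time of 2 days (a higher number here means that more compound is tolerated, a lower number that less compound is tolerated), compound 1 gives 21 uM and compound 2 gives 14 uM. The change between them is 3-chloro-4-methylphenyl in place of phenyl on an oxygen on a saturated carbon, and the step was a 1.5-fold lower number from compound 1 to compound 2 (0.18 log units; within the scatter). Compound 4 `Cc1ccc2nc(C(C)O)n(CCCCOc3ccc(C)c(Cl)c3)c2c1` is unmeasured and carries the same change against compound 3, namely (3-chloro-4-methylphenyl in place of phenyl on an oxygen on a saturated carbon). The difference between the core of compound 1 and the core of compound 3 is not broken down here. Because the earlier step of a 1.5-fold lower number from compound 1 to compound 2 (0.18 log units; within the scatter) stayed within the scatter, a step of about the same small size is expected from compound 3 to compound 4 in this assay, though with no number for compound 3 the starting point is uncertain. Compound 4 is therefore estimated at 15 uM, with a range of 5 uM to 45 uM.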

Compound 4, half-maximal toxic concentration: 8.6 uM
For compound 4 the middle estimate is 1.7-fold (0.24 log units) above the measured one, and the stated range covers the measured number.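

No step can be read from compound 3 to compound 4 in this assay, since compound 3 has no single number there. The compounds shown leave open whether 3-chloro-4-methylphenyl in place of phenyl acts alike on the core of compound 1 and the core of compound 3. No evidence on a cause is available here.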